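The source may report more compounds than this note shows. Statements on the series, on what has been measured and on what is new or still open speak of the compounds shown alone.

Measured so far in a functional assay on HeLa cells (Homo sapiens) for inhibition, read by MTT assay, with a stated time of 24 h; on this read-out lower numbers stand for stronger inhibition and higher numbers for weaker inhibition:
compound 1 `CCOC(=O)C1=Cc2ccccc2OC1(OCc1cc(-c2ccc(F)cc2F)no1)C(F)(F)F`: > 150000 nM (a limit of the assay)
compound 2 `CCOC(=O)C1=Cc2ccccc2OC1(OCc1cc(-c2ccc(Cl)cc2)no1)C(F)(F)F`: 12300 nM

Among the compounds with values here, compound 2 carries the only real number in this assay; the other entry is a limit of the assay the limit of > 150000 nM in this assay, at which 1 of the 2 values shown sits, and belongs to compound 1. Within the data shown here, the single measured step, an at least 12-fold lower number from compound 1 to compound 2 (1.08 log units; beyond the scatter), swaps the whole aryl group at the far end of the shared core, 2,4-difluorophenyl for 4-chlorophenyl, and was large.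

Compound 3 `CCOC(=O)C1=Cc2ccccc2OC1(OCc1cc(-c2ccc([N+](=O)[O-])cc2)no1)C(F)(F)F` differs from compound 2 by nitro in place of chloro on an aromatic carbon. Among the measured compounds shown here, no measured step exchanges one group at that position for another; the step from compound 1 to compound 2 changes both the number and the kind of substituents, so it shows only that this aryl group matters, not how chloro and nitro compare. The step of a 1.6-fold higher number from compound 2 to compound 3 (0.21 log units; within the scatter) is therefore expected to be small, in either direction, with wide uncertainty. Compound 3 is estimated at 20000 nM, between 5000 nM and 100000 nM.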

Compound 3, half-maximal inhibitory concentration: > 150000 nM
Compound 3 was reported as a limit; the forecaster's own chance of this, stated with the estimate: 20%; middle value at least 7.5-fold (0.87 log units) away from the limit.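

In this assay, nitro in place of chloro on the aromatic carbon gives an at least 12-fold higher number from compound 2 to compound 3 (1.08 log units; beyond the scatter). The earlier step changed both the number and the kind of substituents, whereas this one changes a single group, so one exchange at this position is enough to move the number by a large step. Compound 1 and compound 3 both stand at a limit, and the step between them cannot be read: the limit of > 150000 nM in this assay, at which 2 of the 3 values shown sit.

With only compound 2 giving a real number, the compounds shown leave open whether chloro is unusual at this position or whether a bromo, methyl, methoxy or amine group there would also give a measurable number. They also leave open how a plain phenyl group without any substituent compares with the 4-chlorophenyl group.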